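The source may hold more compounds than are shown below. What is called first, only, known or untested is meant among the compounds shown, and "the series" means these compounds.

Measured compounds:
- compound 1, `C=CC(=O)NCCCCc1ccc2ncn(-c3ccnc(N)n3)c2c1`: in an assay on Sf9 cells for inhibition of mitogen-activated protein kinase kinase kinase 14 variant S549D (Homo sapiens), with a stated time of 30 min, in the presence of a further agent that is not named here (on this read-out lower numbers stand for stronger inhibition and higher numbers for weaker inhibition), compound 1 gives 501000 nM
- compound 2, `C#Cc1cccc(C#Cc2ccc3ncn(-c4ccnc(N)n4)c3c2)n1`: in this assay compound 2 gives 3160 nM

Of these two numbers, compound 2 stands at the lower end, and since lower numbers stand for stronger inhibition, compound 2 is the stronger inhibitor of the pair; the gap to compound 1 is far beyond the usual scatter of the measurement.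

The next compound, compound 3, `C#Cc1nccc(C#Cc2ccc3ncn(-c4ccnc(N)n4)c3c2)n1`, keeps the whole of compound 2 except for one exchange: a group of 8 heavy atoms (6 carbon, 2 nitrogen; one six-membered aromatic ring with 2 hetero atoms) in place of a group of 8 heavy atoms (7 carbon, 1 nitrogen; one six-membered aromatic ring with 1 hetero atom), on a triple-bonded carbon. The rest of the molecule, including the shared core and the triple bond that carries the exchanged ring, is unchanged.

Going by the values given here, no measured pair shows what this kind of exchange does in this assay, so there is no step to lean on. The change swaps one small aromatic ring for a closely similar one at the same place. The step is expected to be modest, in either direction, and most likely not beyond the scatter. Compound 3 is therefore expected to give about 3500 nM in this assay, with a likely range of 1000 nM to 12000 nM, which means an expected step of a 1.1-fold higher number from compound 2 to compound 3 (0.04 log units; within the scatter).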

Compound 3, half-maximal inhibitory concentration: 39800 nM
Compound 3: the middle estimate sits 11-fold (1.06 log units) below what was measured; the whole stated range lies below it.
By their numbers in this assay, from the lowest: compound 2; then compound 3; then compound 1.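

In this assay, the exchange gives a 13-fold higher number from compound 2 to compound 3 (1.10 log units; beyond the scatter), so this place on a triple-bonded carbon is sensitive to which ring it carries, and the change is towards weaker inhibition. The two groups have the same count of 8 heavy atoms and each holds one six-membered aromatic ring, yet going from 7 carbon and 1 nitrogen to 6 carbon and 2 nitrogen, with 2 hydrogen-bond acceptors in place of 1 hydrogen-bond acceptor, is enough to produce a step well beyond the scatter. Nothing measured here explains why the number rises.

With only this one exchange shown, it remains open whether the step comes from having a second ring nitrogen at all or from where that nitrogen lies in the ring. Also open, going by these compounds, are what an amine or a methoxy group on this ring would do to the number, and whether the same exchange would give a step of similar size on another compound.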